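A few compounds are considered here, and "the series" means these few. Any claim that something is new, unique, unknown or untested is made for them only; others in the source may bear on it.

In a functional assay on HepG2 cells (Homo sapiens) for antiproliferative activity, read by spectrophotometry, with a stated time of 2 days (on this read-out lower numbers stand for stronger inhibition of growth and higher numbers for weaker inhibition of growth), three compounds are measured, each only as a limit:
- compound 1 `Cc1ccc(Nc2ncc(C(F)(F)F)c(N3Cc4cccc(N(C)S(C)(=O)=O)c4C3)n2)cc1C` gives > 30000 nM as a limit
- compound 2 `COc1ccc(C(F)(F)F)cc1Nc1ncc(C(F)(F)F)c(N2Cc3cccc(N(C)S(C)(=O)=O)c3C2)n1` gives > 30000 nM as a limit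
- compound 3 `Cc1cc(C)cc(Nc2ncc(C(F)(F)F)c(N3Cc4cccc(N(C)S(C)(=O)=O)c4C3)n2)c1` gives > 30000 nM as a limit

Compound 3 thus gives > 30000 nM as a limit and no number. All three stand alike (the limit of > 30000 nM in this assay, at which 3 of the 3 values shown sit). In compound 4 `CN(c1cccc2c1CN(c1nc(Nc3cccc(C(F)(F)F)c3)ncc1C(F)(F)F)C2)S(C)(=O)=O` 3-(trifluoromethyl)phenyl stands in place of 3,5-dimethylphenyl on a nitrogen on an aromatic ring (3-(trifluoromethyl)phenyl in place of 3,5-dimethylphenyl on a nitrogen on an aromatic ring). Three measured swaps at this place bear on it (a step that the two limits leave unreadable from compound 1 to compound 3) (a step that the two limits leave unreadable from compound 2 to compound 3) (a step that the two limits leave unreadable from compound 1 to compound 2) and none gives a readable size. No step beyond the scatter is therefore expected in this assay and another limit is likely. The expected step is a number no higher from compound 3 to compound 4 (the limit leaves the size open) in this estimate. For compound 4 the estimate is 30000 nM with an expected range (12000 nM to 60000 nM).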

Compound 4, concentration for 50% growth inhibition: > 30000 nM
Compound 4 was reported as a limit; the forecaster's own chance of this, stated with the estimate: 85%; the middle value lies on the limit itself.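

In this assay compound 4 gives > 30000 nM, a limit and not a number, so its steps from compound 1, compound 2 and compound 3 cannot be read. The compounds shown leave open whether any swap of the group on this nitrogen changes growth inhibition at all, as every value stands at one limit: the limit of > 30000 nM in this assay, at which 4 of the 4 values shown sit.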